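Adding a Methyl Group Beside Another on an Aromatic Ring

A few compounds are considered here, and "the series" means these few. Any claim that something is new, unique, unknown or untested is made for them only; others in the source may bear on it.

Of the compounds shown here, three have been measured in an ADME assay on microsomes from liver (Homo sapiens) for metabolic stability, read by LC-MS, using NADPH, with a stated time of 10 min, tested at 0.5 uM; a higher number here means that more of the compound is left, a lower number that less of the compound is left. Compound 1 `Cc1cc(-c2ccnc(C(F)F)c2)ncc1OC[C@@](C)(N)CC(C)C` gives 83%. Among the measured compounds shown here, compound 2 `Cc1cc(-c2cc(C)c(OC[C@@](C)(N)CC(C)C)cn2)ccn1` gives 79%, and the only one-place step among the measured compounds, a number 4 percentage points lower from compound 1 to compound 2 (within the scatter), lies within the scatter, so these two numbers cannot be told apart. Compound 3 `COC(=O)Nc1cc(-c2ccc(OC[C@@](C)(N)CC(C)C)c(C)c2)ccn1` gives 98%, the highest of the three numbers; its distance to compound 1 and its larger distance to compound 2 both lie beyond the scatter, so compound 3 clearly leaves more of the compound behind than either of them.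

Compound 4 `COC(=O)Nc1cc(-c2ccc(OC[C@@](C)(N)CC(C)C)c(C)c2C)ccn1` is built from compound 3 by a single change: methyl in place of hydrogen on an aromatic carbon. For the measured compounds named here, no measured step adds a methyl in place of hydrogen, so the record offers no direct guide. Going by the values given here, the one measured step, a number 4 percentage points lower from compound 1 to compound 2 (within the scatter), exchanged groups on a different ring and stayed within the scatter, which suggests that small changes on an aromatic carbon need not move this read-out much. Compound 3 already sits close to the top of the scale, which leaves little room to rise.

The expectation for compound 4 is therefore a number near that of compound 3, with the step of a number 6 percentage points lower from compound 3 to compound 4 (within the scatter) estimated to stay within the scatter, giving an estimate of 92% with a range from 78% to 99%.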

Compound 4, percent of the compound remaining: 93%
The estimate for compound 4 lay 1 percentage points below the measured number, and the stated range covers the measured number.
By their numbers in this assay, from the lowest: compounds 2, 1, 4 and 3 (each within the scatter of the next, the first and the last beyond it).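

In this assay, the step of a number 5 percentage points lower from compound 3 to compound 4 (within the scatter) is the only measured case of methyl in place of hydrogen, and it shows that the two numbers cannot be told apart. The earlier compounds shown here said nothing about this position: here, an aromatic carbon ortho to a large group, ortho to a methyl group and meta to a (2-amino-2,4-dimethylpentyl)oxy group takes on a methyl with no change that this read-out can separate from the scatter. The compounds shown contain nothing that bears on the reason for this result.

Going by these compounds, it remains open whether an ethyl group, a methoxy group or a fluorine atom on this same aromatic carbon would also leave the number within the scatter of compound 3 at 98%. On these data alone, compound 3 and compound 4 both stand near the top of the scale, so it is also open whether the same added methyl would look as harmless on a compound with more room to move, such as compound 2 at 79%.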